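This account rests on a few compounds, and the source may have more. Where it says the series, first, only, none or still open, it means among the compounds named here.

Measured so far:
- compound 1 `COc1ccc(-c2ccnc(Nc3ccc(Cl)cc3Cl)n2)cc1`: 4170 nM
- compound 2 `COc1cccc(Nc2nccc(-c3ccc(Br)cc3)n2)c1`: 278000 nM

In a functional assay on MCF7 cells (Homo sapiens) for antiproliferative activity, read by MTT assay (on this read-out lower numbers stand for stronger inhibition and higher numbers for weaker inhibition), compound 2 gives 278000 nM, the highest of the two numbers; compound 1 gives 4170 nM, a much lower number, but the two structures differ in more than one place, so the pair shows only its two values. Compound 3 `COc1ccc(-c2ccnc(Nc3cccc(OC)c3)n2)cc1` is not yet measured. It arises from compound 2 by methoxy in place of bromo on an aromatic carbon. Compound 3 thereby carries the same methoxy-bearing aryl as compound 1. The step from compound 2 to compound 3 is expected to be downward and beyond the scatter, a 5.6-fold lower number from compound 2 to compound 3 (0.75 log units; beyond the scatter). Compound 3 is estimated at 50000 nM, within 10000 nM to 250000 nM.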

Compound 3, half-maximal inhibitory concentration: 3450 nM
The estimate for compound 3 lay 14-fold (1.16 log units) above the measured number; the whole stated range lies above it.
By their numbers in this assay, from the lowest: compounds 3 and 1 (each within the scatter of the next); then compound 2.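

Methoxy in place of bromo on this aromatic carbon, para to a large group, gives an 81-fold lower number from compound 2 to compound 3 (1.91 log units; beyond the scatter) in this assay as the first change in the series made in one place alone. This carbon is therefore sensitive to the identity of its substituent, at least within this pair, and the size of the step shows that a single-group exchange here can move the read-out substantially. Nothing available explains the step.

As far as these compounds go, whether it reflects the arrival of methoxy or the departure of bromo remains open. An amine, a hydroxy group or a longer alkoxy chain on this carbon would help separate the two.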